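The source may report more compounds than this note shows. Statements on the series, on what has been measured and on what is new or still open speak of the compounds shown alone.

In a functional assay on A549 cells (Homo sapiens) for antiproliferative activity, read by MTT assay, with a stated time of 48 h (on this read-out lower numbers stand for stronger inhibition and higher numbers for weaker inhibition), compound 1 `C/C(=C\CC/C(C)=C/CC[C@@H]1[C@@]2(C)CCC(=O)C(C)(C)[C@H]2CC[C@@]1(C)O)CC/C=C(\C)C(=O)OCc1cn(C[C@@H]2O[C@H](n3ccc(=O)[nH]c3=O)[C@H]3OC(C)(C)O[C@H]32)nn1` gives 15300 nM and compound 3 `C/C(=C\CC/C(C)=C/CC[C@@H]1[C@@]2(C)CCC(=O)C(C)(C)[C@H]2CC[C@@]1(C)O)CC/C=C(\C)C(=O)OCc1cn(C[C@@H]2O[C@H](n3ccc(=O)[nH]c3=O)C[C@H]2O)nn1` gives 28100 nM. Compound 2 `C/C(=C\CC/C(C)=C/CC[C@@H]1[C@@]2(C)CCC(=O)C(C)(C)[C@H]2CC[C@@]1(C)O)CC/C=C(\C)C(=O)OCc1cn(-c2ccc(F)c(Cl)c2)nn1` is reported only as a limit, > 150000 nM. That limit is the limit of > 150000 nM in this assay, at which 1 of the 3 values shown sits. Compound 4 `C/C(=C\CC/C(C)=C/CC[C@@H]1[C@@]2(C)CCC(=O)C(C)(C)[C@H]2CC[C@@]1(C)O)CC/C=C(\C)C(=O)OCc1cn(-c2cccc(F)c2)nn1` differs from compound 2 by the exchange (3-fluorophenyl in place of 3-chloro-4-fluorophenyl on an aromatic nitrogen). For the measured compounds named here, because compound 2 stands at the limit of > 150000 nM in this assay, at which 1 of the 3 values shown sits, no measured step is available from which the size of the change from compound 2 to compound 4 could be read. The exchange is small, so compound 4 is expected to remain near that limit, with an expected step that the limit leaves unreadable from compound 2 to compound 4, which amounts to none beyond the scatter. In this assay compound 4 is therefore estimated at 200000 nM, with a range from 60000 nM to 700000 nM.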

Compound 4, half-maximal inhibitory concentration: 124000 nM
For compound 4 the middle estimate is 1.6-fold (0.21 log units) above the measured one, and the stated range covers the measured number.
By their numbers in this assay, from the lowest: compounds 1 and 3 (each within the scatter of the next); then compound 4. At a limit, above all of these: compound 2.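

In this assay, compound 4, with 3-fluorophenyl in place of 3-chloro-4-fluorophenyl on the aromatic nitrogen, gives 124000 nM, a readable number for a compound with a phenyl group at this position. Compound 2 is held at a limit and not a number: the limit of > 150000 nM in this assay, at which 1 of the 4 values shown sits. The exchange therefore gives an at least 1.2-fold lower number from compound 2 to compound 4 (0.08 log units; that floor lies within the scatter), and no larger change can be claimed from this pair. Still open, going by these compounds, is how an aminophenyl, a carboxyphenyl or a benzyl group on that aromatic nitrogen would read in this assay.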